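A few compounds are considered here, and "the series" means these few. Any claim that something is new, unique, unknown or untested is made for them only; others in the source may bear on it.

Compound 1 `Cn1nnnc1SCC(=O)N/N=c1/scc(-c2ccccc2)n1-c1ccccc1`: in an ADME assay on NIH3T3 cells (Mus musculus) for cytotoxicity, read by MTT assay, with a stated time of 24 h (on this read-out lower numbers stand for stronger inhibition and higher numbers for weaker inhibition), compound 1 gives 173 ug/mL.
Compound 2 `Cc1nnc(SCC(=O)N/N=c2/scc(-c3ccc(C#N)cc3)n2-c2ccccc2)s1`: in this assay compound 2 gives only a limit of the assay, < 3.9 ug/mL.
Compound 3 `O=C(CSc1nnnn1-c1ccccc1)N/N=c1/scc(-c2ccccc2)n1-c1ccccc1`: in this assay compound 3 gives 417 ug/mL.

Among the two numbers that were read out, compound 3 stands highest, meaning it is the weakest inhibitor of these mouse fibroblast cells; the nearest is compound 1, reached by the step of a 2.4-fold higher number from compound 1 to compound 3 (0.38 log units; beyond the scatter), which is a modest change from phenyl in place of methyl on an aromatic nitrogen. Compound 2 contributes no number, only the limit (the limit of < 3.9 ug/mL in this assay, at which 1 of the 3 values shown sits).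

The unmeasured compound 4 `O=C(CSc1nnnn1-c1ccccc1)N/N=c1/scc(-c2ccc([N+](=O)[O-])cc2)n1-c1ccccc1` keeps the whole of compound 3 and changes it in one place: nitro in place of hydrogen on an aromatic carbon. For the measured compounds named here, no measured step follows exactly this change. Going by the values given here, the only measured step, from compound 1 to compound 3, alters a different part of the molecule and was modest. Compound 2, which carries a nitrile on the same phenyl ring but also a different heterocycle, gives only a limit, so it cannot be set beside compound 3 as a clean comparison. Because compound 2 sits at the limit (the limit of < 3.9 ug/mL in this assay, at which 1 of the 3 values shown sits), a drop from compound 3 to compound 4 seems likelier than a rise, but its size is uncertain. Compound 4 is therefore expected to give 80 ug/mL, within 8 ug/mL to 400 ug/mL, an expected step of a 5.2-fold lower number from compound 3 to compound 4 (0.72 log units; beyond the scatter).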

Compound 4, half-maximal inhibitory concentration: 14.3 ug/mL
For compound 4 the middle estimate is 5.6-fold (0.75 log units) above the measured one; the measured number falls inside the stated range.
By their numbers in this assay, from the lowest: compound 4; then compound 1; then compound 3. At a limit, below all of these: compound 2.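

Replacing phenyl with 4-nitrophenyl gives a 29-fold lower number from compound 3 to compound 4 (1.46 log units; beyond the scatter), which shows that in this assay the read-out responds strongly to a change at this position, para to a large group on a six-membered aromatic ring of carbon only. For the compounds shown here, this large step contrasts with the modest 2.4-fold higher number from compound 1 to compound 3 (0.38 log units; beyond the scatter), the only other measured step, which lies in a different part of the molecule, on an aromatic nitrogen. Compound 2 also carries a group at this position, a nitrile, but it differs from compound 3 in more than one place, so it offers no clean comparison, and its value is only a limit: the limit of < 3.9 ug/mL in this assay, at which 1 of the 4 values shown sits.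

On these data alone, with a single group to read at this position in a one-place comparison, it remains open whether the large drop is particular to nitro or would also follow from an amine, a methoxy group or a chlorine atom. Also open, as far as these compounds go, is whether nitro would give a step of similar size on compound 1, which has methyl in place of phenyl on the aromatic nitrogen.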